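The compounds below may be only part of what the source reports. "The series", "measured", "known", "first", "only" and "open" are said of these compounds alone.

In a functional assay on HOP-62 cells (Homo sapiens) for inhibition, read by sulforhodamine B assay, with a stated time of 48 h, tested at 10 uM (on this read-out lower numbers stand for less inhibition of growth and higher numbers for more inhibition of growth at the one concentration tested), compound 2 `Clc1ccc(-c2cn3nc(-c4ccccc4)nc3s2)cc1` gives 40%. That figure lies within the scatter of compound 1 `COc1ccc(-c2nc3sc(-c4ccccc4)cn3n2)cc1` at 49%, and clearly under compound 3 `COc1ccc(-c2nc3sc(-c4ccc(Cl)cc4)cn3n2)cc1` at 60.4%.

The next compound, compound 4 `c1ccc(-c2nc3sc(-c4ccccc4)cn3n2)cc1`, has not yet been measured. It differs from compound 2 by one small edit, hydrogen in place of chloro on an aromatic carbon, so that 4-chlorophenyl becomes phenyl.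

The closest evidence is the same swap in the opposite direction. Chloro in place of hydrogen on an aromatic carbon gave a number 11.4 percentage points higher from compound 1 to compound 3 (beyond the scatter), a modest step beyond the scatter. Reversing that swap suggests a fall of similar size. The other measured step, a number 20.4 percentage points higher from compound 2 to compound 3 (beyond the scatter), comes from methoxy in place of hydrogen, a different edit, so it bears on compound 4 only indirectly. It does show that compound 2 has room to differ when its substituents change.

The expected change is a number 11 percentage points lower from compound 2 to compound 4 (beyond the scatter), a modest estimated drop. For compound 4 the expected value is 29%, with an estimated range of 16% to 42%.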

Compound 4, percent growth inhibition at one concentration: 33%
Compound 4: the middle estimate sits 4 percentage points below what was measured; measured number inside the range.
By their numbers in this assay, from the lowest: compounds 4, 2 and 1 (each within the scatter of the next, the first and the last beyond it); then compound 3.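

Replacing 4-chlorophenyl with phenyl in a molecule without a methoxy group gives a number 7 percentage points lower from compound 2 to compound 4 (within the scatter), so on its own this step cannot be told apart from noise. That does not make the chloro step different from the one seen with methoxy present, since the two sizes agree: the same change on two cores in this assay, a number 11.4 percentage points higher (beyond the scatter) from compound 1 to compound 3 and a number 7 percentage points higher (within the scatter) from compound 4 to compound 2, 4.4 percentage points apart, within the scatter of two such steps. Removing methoxy now gives a second reading of that group, a number 16 percentage points lower from compound 1 to compound 4 (beyond the scatter), and it matches the first: the same change on two cores in this assay, a number 20.4 percentage points higher (beyond the scatter) from compound 2 to compound 3 and a number 16 percentage points higher (beyond the scatter) from compound 4 to compound 1, 4.4 percentage points apart, within the scatter of two such steps.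

On these data alone, only hydrogen, chloro and methoxy appear at these places, so it remains open how an amine, a carboxylic acid or a longer chain on the same ring would change growth inhibition. Each number also comes from a single concentration, which leaves open how these compounds would compare across a range of concentrations.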